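Bromo in Place of Methoxy: Expecting Compound 3

The source may hold more compounds than are shown below. What is called first, only, known or untested is meant among the compounds shown, and "the series" means these compounds.

Compound 2 `COc1cccc(NC(=O)C2CCN(C/C=C/c3ccccc3)CC2)c1` was tested in a functional assay on HepG2 cells (Homo sapiens) for inhibition, read by MTT assay, with a stated time of 72 h (a higher number here means a weaker inhibitor, a lower number a stronger inhibitor), where compound 2 gives 78600 nM. Among the compounds with values here, that is the highest of the two numbers so far: compound 1 `CCc1ccc(NC(=O)C2CCN(C/C=C/c3ccccc3)CC2)cc1` gives 23300 nM, and the step of a 3.4-fold higher number from compound 1 to compound 2 (0.53 log units; beyond the scatter). Compound 3 `O=C(Nc1cccc(Br)c1)C1CCN(C/C=C/c2ccccc2)CC1` has not yet been measured; compared with compound 2 it differs by bromo in place of methoxy on an aromatic carbon. Within the data shown here, no measured step shows bromo replacing methoxy, and the single step available swaps a different group, so it offers only loose guidance. A modest lower number is expected, a 2.0-fold lower number from compound 2 to compound 3 (0.29 log units; within the scatter). Compound 3 is therefore estimated at 40000 nM, with a range from 15000 nM to 110000 nM.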

Compound 3, half-maximal inhibitory concentration: 19200 nM
Beside the measured number, compound 3's estimate is 2.1-fold (0.32 log units) above it, and the stated range covers the measured number.
By their numbers in this assay, from the lowest: compounds 3 and 1 (each within the scatter of the next); then compound 2.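

Within the data shown here, at this position on the aromatic ring, the choice of group clearly matters in this assay: bromo in place of methoxy gives a 4.1-fold lower number from compound 2 to compound 3 (0.61 log units; beyond the scatter) with only that one group changed. Against the other neighbour there is a 1.2-fold lower number from compound 1 to compound 3 (0.08 log units; within the scatter), so 3-bromophenyl and 4-ethylphenyl cannot be separated here. No measurement shown explains the difference between bromo and methoxy.

As far as these compounds go, whether an amine or a carboxylic acid at this position would give a lower or higher number than bromo remains open.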